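The source may hold more compounds than are shown below. What is called first, only, known or untested is meant among the compounds shown, and "the series" means these compounds.

In a functional assay on HL-60 cells (Homo sapiens) for cytotoxicity, read by MTT assay (on this read-out lower numbers stand for stronger inhibition and higher numbers for weaker inhibition), three compounds sharing one core have numbers: compound 1 `Cc1ccccc1S(=O)(=O)NC(C1=CC(=O)c2c(O)ccc(O)c2C1=O)C(C)C` gives 190 nM and compound 2 `COc1ccc(S(=O)(=O)NC(C2=CC(=O)c3c(O)ccc(O)c3C2=O)C(C)C)c(OC)c1` gives 400 nM while compound 3 `Cc1ccccc1S(=O)(=O)NC(C)C1=CC(=O)c2c(O)ccc(O)c2C1=O` gives 70 nM as the lowest of the three. Compound 4 `CC(NS(=O)(=O)c1ccccc1Br)C1=CC(=O)c2c(O)ccc(O)c2C1=O` differs from compound 3 in one place (bromo in place of methyl on an aromatic carbon): bromo in place of methyl on an aromatic carbon, ortho to a large group. For the measured compounds named here, only one measured step touches this ring, replacing 2-methylphenyl with 2,4-dimethoxyphenyl (a 2.1-fold higher number from compound 1 to compound 2 (0.32 log units; beyond the scatter)). The other modest step lies on the chain (a 2.7-fold lower number from compound 1 to compound 3 (0.43 log units; beyond the scatter)). Neither exchanges methyl for bromo, so no step beyond the scatter is expected in this assay here. The estimated change is small (a 1.1-fold higher number from compound 3 to compound 4 (0.06 log units; within the scatter)). Compound 4 is estimated at 80 nM with an expected range of 35 nM to 190 nM in this measurement.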

Compound 4, half-maximal inhibitory concentration: 120 nM
For compound 4 the middle estimate is 1.5-fold (0.18 log units) below the measured one; the measured number falls inside the stated range.
By their numbers in this assay, from the lowest: compounds 3, 4 and 1 (each within the scatter of the next, the first and the last beyond it); then compound 2.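

In this assay putting bromo in place of methyl on an aromatic carbon, ortho to a large group, gives a 1.7-fold higher number from compound 3 to compound 4 (0.23 log units; within the scatter) and so separates the two groups by no more than repeat measurements would. The earlier step on this ring swapped 2-methylphenyl for 2,4-dimethoxyphenyl and so changed more than one group, whereas this one changes a single group. Here, 2-bromophenyl and 2-methylphenyl read alike.

From the compounds shown here alone, whether an amine or a carboxylic acid at this place would read the same stays open. Nothing available explains the likeness of bromo and methyl here.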